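The compounds below may be only part of what the source reports. "The series", "measured", "known", "first", "only" and "open" are said of these compounds alone.

In an in vitro ADME assay on microsomes from liver (Homo sapiens) for metabolic stability, read by LC-MS (on this read-out higher numbers stand for a longer-lived compound and lower numbers for a shorter-lived compound), compound 1 `CC(C)N1C(=O)C(=O)N=C1/N=C(/Nc1ccc(Cl)c(Cl)c1)NC(C)(C)C` gives > 1 h, which is a limit and not a number. Compound 2 `CC(C)N1C(=O)C(=O)N=C1/N=C(\NCc1ccccc1)Nc1ccc(Cl)c(Cl)c1` gives > 1 h, again only a limit. Among the compounds with values here, the single measured step, a step that the two limits leave unreadable from compound 1 to compound 2, has no readable size, and all that bears on it is the limit of > 1 h in this assay, at which 2 of the 2 values shown sit. Compound 3 `CCCCCCN/C(=N\C1=NC(=O)C(=O)N1C(C)C)Nc1ccc(Cl)c(Cl)c1` differs from compound 2 by pentyl in place of phenyl on a saturated chain carbon bound to an amine nitrogen. Within the data shown here, with no sized step to draw on, no direction can be read, and the expected change is a step that the limit leaves unreadable from compound 2 to compound 3. For compound 3 the estimated half-life is 1.5 h, with an expected range of 0.6 h to 4 h.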

Compound 3, half-life: 0.131 h
Beside the measured number, compound 3's estimate is 11-fold (1.06 log units) above it; measured number below the stated range.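

In this assay, this amine nitrogen substituent now shows a readable effect, which the earlier pair could not: pentyl in place of phenyl on a saturated chain carbon bound to an amine nitrogen gives an at least 7.6-fold lower number from compound 2 to compound 3 (0.88 log units; beyond the scatter). The change from tert-butyl to hexyl on the amine nitrogen gives an at least 7.6-fold lower number from compound 1 to compound 3 (0.88 log units; beyond the scatter). Both sizes are only lower bounds, resting on a limit of the assay: the limit of > 1 h in this assay, at which 2 of the 3 values shown sit.

On these data alone, how far compound 1 and compound 2 truly lie above compound 3 remains open. So does whether a shorter chain such as butyl, or a cyclohexylmethyl group, on this amine nitrogen would keep the half-life of the benzyl compound or fall with hexyl.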